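Swapping the Aryl Ring: What to Expect for Compound 4

The source may hold more compounds than are shown below. What is called first, only, known or untested is meant among the compounds shown, and "the series" means these compounds.

Compound 1, `Cc1nc(C(NC(=O)C(=O)Nc2ccc(Cl)cc2)C2CCNCC2)sc1CCO`, gives 85400 nM in an ADME assay on TZM-b1 cells (Homo sapiens) for cytotoxicity, read by XTT assay, with a stated time of 3 days; a higher number here means that more compound is tolerated, a lower number that less compound is tolerated. Compound 2, `Cc1nc(C(NC(=O)C(=O)Nc2ccc(F)cc2)C2CCCCN2)sc1CCO`, gives > 88000 nM in this assay, a limit of the assay. Compound 3, `Cc1nc(C(NC(=O)C(=O)Nc2ccc(F)cc2F)C2CCCCN2)sc1CCO`, gives > 84000 nM in this assay, again a limit of the assay.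

Compound 3 thus stands at the ceiling of this assay, as described by the limit of > 84000 nM in this assay, at which 1 of the 3 values shown sits, and compound 2 sits at a comparable ceiling, (the limit of > 88000 nM in this assay, at which 1 of the 3 values shown sits). For that reason the step that the two limits leave unreadable from compound 2 to compound 3 cannot be read. Compound 4, `Cc1nc(C(NC(=O)C(=O)Nc2ccc(Cl)cc2)C2CCCCN2)sc1CCO`, differs from compound 3 by 4-chlorophenyl in place of 2,4-difluorophenyl on an amide-type nitrogen. For the measured compounds named here, no measured step carries this exact change; compound 1 also bears a 4-chlorophenyl and its value lies close to these limits. The expected step that the limit leaves unreadable from compound 3 to compound 4 is estimated as none beyond the scatter. Compound 4 is therefore expected near 85000 nM, in a range from 40000 nM to 200000 nM.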

Compound 4, half-maximal cytotoxic concentration: 32800 nM
Estimate against measurement, compound 4: 2.6-fold (0.41 log units) above; the measured number lies below the stated range.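

With the piperidin-2-yl group held fixed, the group on the amide-type nitrogen matters in this assay: there is an at least 2.5-fold lower number from compound 3 to compound 4 (0.40 log units; beyond the scatter), and there is an at least 2.6-fold lower number from compound 2 to compound 4 (0.42 log units; beyond the scatter). With the 4-chlorophenyl held fixed, the piperidine attachment matters too, with a 2.6-fold lower number from compound 1 to compound 4 (0.42 log units; beyond the scatter). The 4-chlorophenyl group alone therefore does not set the number in this assay; it has to be read together with the piperidine it is paired with.

Still open, going by these compounds, is whether a 4-bromophenyl group on the same nitrogen would lower the number further. A piperidin-3-yl group also remains an open case.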